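The source may hold more compounds than are shown below. What is called first, only, known or untested is meant among the compounds shown, and "the series" means these compounds.

Working notes on the series. Of the compounds shown here, three share the same core and have been read in a functional assay for antagonist activity at P2X purinoceptor 7 (Homo sapiens), read by FLIPR and calcium flux; on this read-out lower numbers stand for stronger inhibition and higher numbers for weaker inhibition. Compound 1 `Clc1cccc(-n2ncnc2Nc2ccccc2)c1Cl` gives 363 nM. Compound 2 `Cc1ccccc1Nc1ncnn1-c1cccc(Cl)c1Cl` gives 17.8 nM. Compound 3 `Clc1cccc(-n2ncnc2NCc2cccnc2)c1Cl` gives 117 nM, the second highest of the three numbers: it sits a 3.1-fold lower number from compound 1 to compound 3 (0.49 log units; beyond the scatter) and a 6.6-fold higher number from compound 2 to compound 3 (0.82 log units; beyond the scatter).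

The next compound, compound 4 `Clc1cccc(-n2ncnc2NCc2cccnc2-c2ccsc2)c1Cl`, differs from compound 3 by one change: thiophen-3-yl in place of hydrogen on an aromatic carbon.

Within the data shown here, only one measured step adds a group onto an aromatic carbon of the ring attached to the amine nitrogen, namely a 20-fold lower number from compound 1 to compound 2 (1.31 log units; beyond the scatter). That step is the nearest analogy, although the ring there is a phenyl and the entering group a methyl, whereas here the ring carries a nitrogen and the entering group is thiophen-3-yl. The step of a 6.6-fold higher number from compound 2 to compound 3 (0.82 log units; beyond the scatter) shows that the pyridinylmethyl series and the phenyl series do not run in parallel, so the analogy is loose. A lower number for compound 4 is expected, of smaller size than the methyl step, because a 20-fold lower number from compound 1 to compound 2 (1.31 log units; beyond the scatter) rests on a different ring. The estimated step is a 2.9-fold lower number from compound 3 to compound 4 (0.47 log units; beyond the scatter). For compound 4 the expected value in this assay is 40 nM, with a range of 10 nM to 160 nM.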

Compound 4, half-maximal inhibitory concentration: 15.1 nM
Compound 4: middle estimate off by 2.6-fold (0.42 log units), on the high side; the measured number falls inside the stated range.
By their numbers in this assay, from the lowest: compounds 4 and 2 (each within the scatter of the next); then compound 3; then compound 1.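

The position next to the ring nitrogen, on the six-membered aromatic ring with 1 nitrogen and ortho to a large group, accepts a whole aromatic ring: in this assay, thiophen-3-yl in place of hydrogen gives a 7.7-fold lower number from compound 3 to compound 4 (0.89 log units; beyond the scatter). Among these compounds, until now, the only group added to an aromatic carbon of the ring on the amine nitrogen was a methyl on a phenyl ring, in a 20-fold lower number from compound 1 to compound 2 (1.31 log units; beyond the scatter), so a lower number on adding a group is now seen with two different rings and two different entering groups. No measurement at hand accounts for the size of the new step, and the data give no reason for it.

The compounds shown do not separate the contribution of the sulfur or the five-membered ring from that of simply filling this position, a question that methyl, phenyl, furan-3-yl or dimethylamino at the same carbon would bear on. They also leave open how a carboxylic acid or a longer chain such as butyl would read there, and whether thiophen-3-yl would give a similar step on other rings attached to the amine nitrogen.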